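The source may report more compounds than this note shows. Statements on the series, on what has been measured and on what is new or still open speak of the compounds shown alone.

Of the compounds shown here, three have numbers so far in a functional assay on U-251 cells (Homo sapiens); a lower number here means a stronger inhibitor of growth, a higher number a weaker inhibitor of growth: compound 1 `Cc1cc(C)c2c(O)cc(-c3ccc(Cl)cc3)nc2n1` gives 30200 nM, compound 2 `Oc1cc(-c2ccc(Cl)cc2)nc2ncccc12` gives 39800 nM, and compound 3 `Cc1ccnc2nc(-c3ccc(F)cc3)cc(O)c12` gives 36300 nM. Compound 3 lies within the scatter of both others, so no order can be read among the three values.

The next compound is compound 4 `Cc1ccnc2nc(-c3ccc(Cl)cc3)cc(O)c12`, which differs from compound 3 by chloro in place of fluoro on an aromatic carbon, para to a large group. Among the measured compounds shown here, no measured pair isolates this change, so there is no direct step to carry over. For the measured compounds named here, the only indirect guide is that the two chloro compounds, compound 1 at 30200 nM and compound 2 at 39800 nM, are within the scatter of compound 3 at 36300 nM.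

No change beyond the scatter is therefore expected in this assay, and no direction is favoured. The expected step, a 1.1-fold lower number from compound 3 to compound 4 (0.03 log units; within the scatter), stays within the scatter. Compound 4 is estimated at 34000 nM, with an expected range of 20000 nM to 58000 nM.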

Compound 4, concentration for 50% growth inhibition: 4570 nM
The estimate for compound 4 lay 7.4-fold (0.87 log units) above the measured number; measured number outside the range, below it.
By their numbers in this assay, from the lowest: compound 4; then compounds 1, 3 and 2 (each within the scatter of the next).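

In this assay, among the compounds shown here, chloro in place of fluoro on an aromatic carbon, para to a large group, is a real change (a 7.9-fold lower number from compound 3 to compound 4 (0.90 log units; beyond the scatter)), which the earlier compounds could not show. The methyl also counts in both directions: adding methyl in place of hydrogen on an aromatic carbon gives (an 8.7-fold lower number from compound 2 to compound 4 (0.94 log units; beyond the scatter)), while the step with hydrogen in place of methyl on an aromatic carbon gives (a 6.6-fold lower number from compound 1 to compound 4 (0.82 log units; beyond the scatter)), so the lowest number here needs the chloro together with this particular methyl pattern. Nothing available explains these steps.

From the compounds shown here alone, whether the chloro step holds on the cores of compound 1 and compound 2 remains open. Also open, going by these compounds, is how bromo or methoxy at that place, or an ethyl or longer chain in place of the methyl, would compare with compound 4.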